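This account rests on a few compounds, and the source may have more. Where it says the series, first, only, none or still open, it means among the compounds named here.

In a functional assay for inhibition of sodium/hydrogen exchanger (Oryctolagus cuniculus) (a higher number here means a weaker inhibitor, a lower number a stronger inhibitor), compound 1 `CCCCCc1cc(C)c(C(=O)N=C(N)N)cc1S(C)(=O)=O` gives 27 nM, and compound 2 `Cc1cc(Sc2cccc(Cl)c2)c(S(C)(=O)=O)cc1C(=O)N=C(N)N` gives 37 nM, a number that sits within the scatter of compound 1, so the two stand level. Compound 3 `Cc1cc(Oc2ccccc2)c(S(C)(=O)=O)cc1C(=O)N=C(N)N` differs from compound 2 by phenoxy in place of (3-chlorophenyl)sulfanyl on an aromatic carbon. Among the compounds with values here, the only measured step, a 1.4-fold higher number from compound 1 to compound 2 (0.14 log units; within the scatter), also swapped a group at this same position of the shared core and stayed within the scatter. Because a 1.4-fold higher number from compound 1 to compound 2 (0.14 log units; within the scatter) showed no movement beyond the scatter, no step beyond the scatter is expected for compound 3 either, so a 1.2-fold higher number from compound 2 to compound 3 (0.09 log units; within the scatter) is the expected change. For compound 3 the estimate is 45 nM, within a range from 18 nM to 110 nM.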

Compound 3, half-maximal inhibitory concentration: 10 nM
Compound 3: the middle estimate sits 4.5-fold (0.65 log units) above what was measured; measured number below the stated range.
By their numbers in this assay, from the lowest: compound 3; then compounds 1 and 2 (each within the scatter of the next).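

This position can move the number beyond the scatter in this assay, with a 3.7-fold lower number from compound 2 to compound 3 (0.57 log units; beyond the scatter) and a 2.7-fold lower number from compound 1 to compound 3 (0.43 log units; beyond the scatter). Pentyl and (3-chlorophenyl)sulfanyl stood level here, but phenoxy gives the lowest number of the three compounds, so the position does not treat every group alike. Nothing measured here accounts for the gain with phenoxy.

Phenoxy differs from (3-chlorophenyl)sulfanyl both in having oxygen for sulfur and in lacking the chlorine, and these two changes cannot be told apart here. As far as these compounds go, a 3-chlorophenoxy or plain phenylsulfanyl group would separate them, and how an amine would behave at this position remains open.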